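Tetrazole series: metabolic stability notes, compound 3 to compound 4

This account rests on a few compounds, and the source may have more. Where it says the series, first, only, none or still open, it means among the compounds named here.

Values in an ADME assay on S9 fraction from liver (Rattus norvegicus) for metabolic stability, read by LC-MS, using NADPH, with a stated time of 30 min; a higher number here means that more of the compound is left, a lower number that less of the compound is left:
- compound 1 `CCCCCCCCc1ccc(OCC(=O)Cn2nnc(C)n2)cc1`: < 5%, a limit of the assay
- compound 2 `CCCCCCCCc1ccc(OCC(=O)Cn2nnc(Cc3ccccc3)n2)cc1`: < 5%, a limit of the assay
- compound 3 `CCCCCCCCc1ccc(OCC(=O)Cn2nnnc2-c2cccc(Cl)c2)cc1`: 41%

In this assay compound 1 gives < 5%, which is a limit and not a number. Compound 2 likewise gives < 5%, again a limit. For the measured compounds named here, compound 3 gives 41%, the only number in the set. The other two values are limits, as the limit of < 5% in this assay, at which 2 of the 3 values shown sit, shows. Going by the values given here, the single measured step, a step that the two limits leave unreadable from compound 1 to compound 2, cannot be sized because both of its ends sit at the limit of < 5% in this assay, at which 2 of the 3 values shown sit.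

Compound 4 `CCCCCCCCc1ccc(OCC(=O)Cn2nnnc2-c2cccc(C(=O)O)c2)cc1` differs from compound 3 by carboxy in place of chloro on an aromatic carbon. Among the compounds with values here, no measured step touches this place: the step from compound 1 to compound 2 concerns a different position and yields no readable size. There is therefore nothing in the measured data from which the direction or size of the change in this assay can be read, and the expectation rests on compound 3 alone, with a wide range around its value of 41%.

Compound 4 is expected to give about 50% in this assay, within a range from 25% to 85%. The step this estimate implies is a number 9 percentage points higher from compound 3 to compound 4 (within the scatter), expected but not supported by any measured step.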

Compound 4, percent of the compound remaining: < 5%
Compound 4: a limit, no number; the forecaster's own chance of this, stated with the estimate: 5%; middle value at least 45 percentage points from the limit.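

For the compounds shown here, the change from 3-chlorophenyl to 3-carboxyphenyl gives the first step that can be read in this assay, and it reads as a number at least 36 percentage points lower from compound 3 to compound 4 (beyond the scatter). The group on this aromatic carbon is therefore not indifferent in this read-out: it is the only difference between the two compounds, whereas the earlier step concerned another position and could not be read. The step has a bound and not an exact size, as compound 4 carries a limit and not a number: the limit of < 5% in this assay, at which 3 of the 4 values shown sit.

With only chloro and carboxy shown at this place, it stays open whether other groups on the same aromatic carbon, such as an amine, a methyl ester or a nitrile, would leave more or less of the compound in this assay than these two. As far as these compounds go, it is equally open whether a change elsewhere, for instance a shorter alkyl chain on the shared core, would move compound 4 off its limit.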